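Methylsulfanyl enters a series that sits at the limit

The source may report more compounds than this note shows. Statements on the series, on what has been measured and on what is new or still open speak of the compounds shown alone.

Three analogues share one core. Compound 1 `COc1cc(-n2ncnc2-c2cccc([N+](=O)[O-])c2)cc(OC)c1OC` carries a nitro group; in a functional assay on MCF7 cells (Homo sapiens) for antiproliferative activity, read by MTT assay, with a stated time of 72 h (on this read-out higher numbers stand for weaker inhibition and lower numbers for stronger inhibition), compound 1 gives only the limit > 10000 nM. Compound 2 `COc1cc(-n2ncnc2-c2ccc(F)cc2)cc(OC)c1OC` carries fluoro; in this assay compound 2 likewise gives only the limit > 10000 nM. Compound 3 `COc1cc(-n2ncnc2-c2ccccc2)cc(OC)c1OC` bears the plain phenyl; in this assay compound 3 again gives only the limit > 10000 nM. The steps a step that the two limits leave unreadable from compound 1 to compound 3 and a step that the two limits leave unreadable from compound 2 to compound 3 therefore cannot be sized, because of the limit of > 10000 nM in this assay, at which 3 of the 3 values shown sit.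

Compound 4 `COc1cc(-n2ncnc2-c2ccc(SC)cc2)cc(OC)c1OC` differs from compound 3 by methylsulfanyl in place of hydrogen on an aromatic carbon. No measured step reads, so nothing shown tells in which direction the change moves this assay. Compound 4 is expected at 5000 nM, within 500 nM to 20000 nM. This estimate means an expected step of an at least 2.0-fold lower number from compound 3 to compound 4 (0.30 log units; that floor lies within the scatter).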

Compound 4, half-maximal inhibitory concentration: 390 nM
Beside the measured number, compound 4's estimate is 13-fold (1.11 log units) above it; the whole stated range lies above it.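

With methylsulfanyl on the aromatic carbon para to a large group, this assay gives this series its first readable steps: an at least 25-fold lower number from compound 3 to compound 4 (1.40 log units; beyond the scatter), and an at least 25-fold lower number from compound 2 to compound 4 (1.40 log units; beyond the scatter). This position can therefore respond in this assay, and the change reads as large whether methylsulfanyl replaces hydrogen or fluoro. Each step starts from a limit, which is why it gives only a floor: the limit of > 10000 nM in this assay, at which 3 of the 4 values shown sit.

The compounds shown leave open whether methoxy, methylsulfonyl or a longer chain such as ethylsulfanyl would read likewise at this carbon. They also leave open whether methylsulfanyl would read the same on another carbon of this ring.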